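A few compounds are considered here, and "the series" means these few. Any claim that something is new, unique, unknown or untested is made for them only; others in the source may bear on it.

Measured compounds:
- compound 1, `COc1cc(/C=N/Nc2nc(-c3ccc(Br)cc3)cs2)cc(Br)c1OC`, giving > 100000 nM in an ADME assay on HUVEC cells (Homo sapiens) for inhibition, read by MTT assay, with a stated time of 48 h; on this read-out higher numbers stand for weaker inhibition and lower numbers for stronger inhibition
- compound 2, `COc1cc(/C=N/Nc2nc(-c3ccc(C(F)(F)F)cc3)cs2)c(Br)c(Br)c1OC`, giving > 100000 nM in this assay

The value for compound 1 is a limit of this assay rather than a number. The value recorded for compound 2 is likewise a limit and not a measured number. Compound 2 therefore stands nowhere in particular among the numbers shown: both recorded values sit at the same limit, because of the limit of > 100000 nM in this assay, at which 2 of the 2 values shown sit, and neither can be placed above or below the other.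

Compound 3, `COc1cc(/C=N/Nc2nc(-c3ccccc3)cs2)c(Br)c(Br)c1OC`, is not yet measured in this assay. Compared with compound 2, the change is hydrogen in place of trifluoromethyl on an aromatic carbon. For the measured compounds named here, no step between two measured compounds has been recorded, so there is no measured change of this kind to lean on. With both measured compounds at the limit, the expected step is a step that the limit leaves unreadable from compound 2 to compound 3, which means no change beyond the scatter is expected. Compound 3 is accordingly estimated at 150000 nM, within a range from 50000 nM to 500000 nM, and the assay is expected most likely to report a limit again.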

Compound 3, half-maximal inhibitory concentration: > 100000 nM
Compound 3: no number, only a limit; the forecaster's own chance of this, stated with the estimate: 80%; the middle value does not contradict the limit.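

In this assay compound 3 gives > 100000 nM which is a limit and not a number. No step can be read from compound 2 to compound 3, since both stop at the same limit: the limit of > 100000 nM in this assay, at which 3 of the 3 values shown sit.

The compounds shown leave open what the actual value of each one is in this assay and whether the differences among them matter there.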